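Replacing the 4-methylpiperazin-1-yl group of compound 3 with piperidine

A few compounds are considered here, and "the series" means these few. Any claim that something is new, unique, unknown or untested is made for them only; others in the source may bear on it.

Going by the values given here, compound 3 `CN1CCN(c2nc(-c3cc(Cl)ccc3Cl)nc3[nH]cnc23)CC1` is one of three compounds measured in an assay on cells for displacement of a labelled ligand from adenosine receptor A3 (Homo sapiens), read by scintillation counting and radioligand binding, with a stated time of 180 min, tested at 10 uM; a lower number here means less inhibition, a higher number more inhibition at the concentration tested (going by the name of the read-out). Its value there is a limit of the assay rather than a number: compound 3 gives > 80%. Compound 1 `CN1CCN(c2nc(-c3ccc(Cl)c(Cl)c3)nc3[nH]cnc23)CC1` likewise reaches a limit, giving > 80% in this assay. Between them, the step that the two limits leave unreadable from compound 1 to compound 3 is therefore not readable, as noted by the limit of > 80% in this assay, at which 2 of the 3 values shown sit. Among the compounds with values here, compound 2 `Cn1cnc2c(N3CCCCC3)nc(-c3cc(Cl)ccc3Cl)nc21`, which carries a piperidin-1-yl group and a methyl on a ring nitrogen of its core, gives 5.4% in this assay, and no single-change step connects it to any other measured compound.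

Compound 4 `Clc1ccc(Cl)c(-c2nc(N3CCCCC3)c3nc[nH]c3n2)c1` differs from compound 3 in one place: piperidin-1-yl in place of 4-methylpiperazin-1-yl on an aromatic carbon. Within the data shown here, no measured step covers this exchange, so the size and direction of the change in this assay cannot be read from the compounds in hand; the only measured compound bearing a piperidin-1-yl group is compound 2, which gives 5.4% in this assay. For compound 4 the expected value in this assay is 45%, with a range from 10% to 85%. The expected step from compound 3 to compound 4 is accordingly estimated as a number at least 35 percentage points lower from compound 3 to compound 4 (beyond the scatter), downward and beyond the scatter, though with wide uncertainty.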

Compound 4, a percentage reported as inhibition, at one concentration (the size of the read-out at that concentration, not a potency): > 80%
Compound 4: only a limit was reported; the forecaster's own chance of this, stated with the estimate: 20%; middle value at least 35 percentage points from the limit.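

In this assay compound 4 gives > 80%, which is a limit of the assay, so a piperidin-1-yl group on this aromatic carbon can sit in a compound that reaches that limit. The piperidin-1-yl group therefore does not by itself go with the low reading of compound 2: with hydrogen in place of methyl on an aromatic nitrogen, the result is a number at least 74.6 percentage points higher from compound 2 to compound 4 (beyond the scatter). The exchange of 4-methylpiperazin-1-yl for piperidin-1-yl cannot be sized, nor can the earlier exchange of dichlorophenyl groups, because these compounds all stop at the same ceiling: the limit of > 80% in this assay, at which 3 of the 4 values shown sit.

Any difference between the 4-methylpiperazin-1-yl and piperidin-1-yl groups, or between the 2,5-dichlorophenyl and 3,4-dichlorophenyl groups, therefore stays hidden above the limit. Also open, as far as these compounds go, is how this position would read with a morpholin-4-yl group or an open-chain amine such as diethylamino, and how the aromatic nitrogen would read with an ethyl group in place of the methyl.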